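The compounds below may be only part of what the source reports. "The series", "measured", "known", "first", "only" and "open" are said of these compounds alone.

Values so far in a functional assay on MV4-11 cells (Homo sapiens) for inhibition, read by resazurin assay, with a stated time of 72 h; a lower number here means a stronger inhibitor of growth, a higher number a weaker inhibitor of growth

compound 1 `COc1ccc(Nc2nccc(-c3sc(SC)nc3C)n2)c(OC)c1` gives 530 nM
compound 2 `COCCSc1nc(C)c(-c2ccnc(Nc3ccc(OC)cc3OC)n2)s1` gives 810 nM
compound 3 `COc1ccc(Nc2nccc(-c3sc(OC)nc3C)n2)c(OC)c1` gives 1400 nM

Compound 3 is separated from the other two by a step beyond the scatter (a 2.6-fold higher number from compound 1 to compound 3 (0.42 log units; beyond the scatter)) and one within it (a 1.7-fold higher number from compound 2 to compound 3 (0.24 log units; within the scatter)). Compound 4 `COc1ccc(Nc2nccc(-c3sc(SCc4cccnc4)nc3C)n2)c(OC)c1` carries ((pyridin-3-yl)methyl)sulfanyl in place of methoxy on an aromatic carbon. For the measured compounds named here, two sulfanyl groups stay within the scatter of each other (a 1.5-fold higher number from compound 1 to compound 2 (0.18 log units; within the scatter)), but no measured compound carries a pyridine ring. Reversing the measured change from compound 1 (a 2.6-fold higher number from compound 1 to compound 3 (0.42 log units; beyond the scatter)) therefore suggests a modest fall in this assay on returning to sulfur. The expected step is similar in size (a 2.3-fold lower number from compound 3 to compound 4 (0.37 log units; beyond the scatter)). Compound 4 is estimated at 600 nM (range 200 nM to 1800 nM).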

Compound 4, concentration for 50% growth inhibition: 270 nM
Beside the measured number, compound 4's estimate is 2.2-fold (0.35 log units) above it, within the range that was stated.
By their numbers in this assay, from the lowest: compounds 4, 1, 2 and 3 (each within the scatter of the next, the first and the last beyond it).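

In this assay, for the compounds shown here, ((pyridin-3-yl)methyl)sulfanyl is the only group at this aromatic carbon that carries a ring, and the position accepts it: the change from methoxy is beyond the scatter (a 5.2-fold lower number from compound 3 to compound 4 (0.71 log units; beyond the scatter)), as is the change from (2-methoxyethyl)sulfanyl (a 3.0-fold lower number from compound 2 to compound 4 (0.48 log units; beyond the scatter)). The step from methylsulfanyl stays within the scatter (a 2.0-fold lower number from compound 1 to compound 4 (0.29 log units; within the scatter)), so the pyridine ring shows no separable gain over that small sulfanyl group. No evidence bears on the cause of these steps. Still open, going by these compounds, is whether the ring nitrogen matters, which benzylsulfanyl or pyridin-4-ylmethylsulfanyl would test, and whether sulfur itself can give way to an amine at this carbon.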